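Aryl swap on the shared core: expected to hold potency

A few compounds are considered here, and "the series" means these few. Any claim that something is new, unique, unknown or untested is made for them only; others in the source may bear on it.

Compound 1 `COc1ccc(-c2nnn(CC(=O)Nc3cc(C)nn3C3CCCCC3)n2)cc1` carries a 4-methoxyphenyl group on the shared core and, in an assay on HEK293 cells for activation of Kir3.1/Kir3.2 (Homo sapiens), read by thallium flux (a higher number here means that more compound is needed for the effect, a lower number that less compound is needed), compound 1 gives 175 nM. Compound 2 `Cc1cc(NC(=O)Cn2nnc(C3CC3)n2)n(C2CCCCC2)n1` has a cyclopropyl there instead; in this assay compound 2 reaches only the limit of > 3000 nM, which is a limit and not a number. Compound 3 `Cc1cc(NC(=O)Cn2nnc(-c3ccc(C(F)(F)F)cc3)n2)n(C2CCCCC2)n1` bears a 4-(trifluoromethyl)phenyl group, and in this assay compound 3 gives 241 nM. Among the numbers shown, compound 3 stands highest, with compound 1 nearest and the two within the scatter of each other.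

The steps seen so far point one way: an at least 17-fold higher number from compound 1 to compound 2 (1.23 log units; beyond the scatter), and an at least 12-fold lower number from compound 2 to compound 3 (1.09 log units; beyond the scatter), both large, while a 1.4-fold higher number from compound 1 to compound 3 (0.14 log units; within the scatter). Exchanging one substituted phenyl for another thus changed little, whereas losing the phenyl altogether cost a great deal, which is underlined by the limit of > 3000 nM in this assay, at which 1 of the 3 values shown sits.

Compound 4 `Cc1cc(NC(=O)Cn2nnc(-c3ccc(Cl)c(C)c3)n2)n(C2CCCCC2)n1` differs from compound 3 in that (4-chloro-3-methylphenyl in place of 4-(trifluoromethyl)phenyl on an aromatic carbon). Since this again replaces one substituted phenyl with another, the step from compound 3 to compound 4 in this assay is expected to stay within the scatter, as a 1.2-fold lower number from compound 3 to compound 4 (0.08 log units; within the scatter). Compound 4 is therefore estimated at 200 nM in this assay, with a range from 70 nM to 700 nM.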

Compound 4, half-maximal effective concentration: 712 nM
Compound 4: middle estimate off by 3.6-fold (0.55 log units), on the low side, and the stated range ends below it.
By their numbers in this assay, from the lowest: compounds 1 and 3 (each within the scatter of the next); then compound 4. At a limit, above all of these: compound 2.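

Compounds 1 and 3 had suggested that one substituted phenyl could stand in for another at this aromatic carbon, but compound 4 shows that the choice of substituents matters: in this assay the 4-chloro-3-methylphenyl group gives a 3.0-fold higher number from compound 3 to compound 4 (0.47 log units; beyond the scatter) and a 4.1-fold higher number from compound 1 to compound 4 (0.61 log units; beyond the scatter), both modest steps. A phenyl group still compares well with a small ring here, since the change from cyclopropyl gives an at least 4.2-fold lower number from compound 2 to compound 4 (0.62 log units; beyond the scatter), a step that rests on a limit and not on a number for compound 2. Nothing shown explains why 4-chloro-3-methylphenyl requires more compound than the other two phenyl groups.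

Compound 4 differs from the other phenyl compounds in carrying both a chlorine and a methyl group, so the compounds shown cannot say whether one of these or the pair accounts for the rise, which a 4-chlorophenyl or a 3-methylphenyl group would help to separate. Also open, as far as these compounds go, is how an unsubstituted phenyl, or a phenyl carrying an amine or a carboxylic acid, would fare at this position.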